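A Shorter Amine Tail on the Shared Core

A few compounds are considered here, and "the series" means these few. Any claim that something is new, unique, unknown or untested is made for them only; others in the source may bear on it.

Of the compounds shown here, three built on the shared core have been measured in a toxicity assay on HEK-293T cells (Homo sapiens) for cytotoxicity, read by MTT assay, with a stated time of 72 h; on this read-out higher numbers stand for weaker inhibition and lower numbers for stronger inhibition. Compound 1 `CN1CCN(CCCCCCn2c3c(c4ccccc42)C(=O)c2c[n+]([O-])c4ccccc4c2C3=O)CC1` gives 5800 nM and stands highest of the three numbers. Compound 2 `CC1(C)O[C@@H](CO)[C@H](Cn2cc(Cn3c4c(c5ccccc53)C(=O)c3c[n+]([O-])c5ccccc5c3C4=O)nn2)O1` gives 120 nM and lies furthest from compound 1. Compound 3 `O=C1c2c[n+]([O-])c3ccccc3c2C(=O)c2c1c1ccccc1n2Cc1cn([C@H]2O[C@H](CO)[C@@H](O)[C@H]2O)nn1` gives 1370 nM and lies nearest to compound 1. Among the compounds with values here, the only step between two measured compounds that differ in a single place is an 11-fold higher number from compound 2 to compound 3 (1.06 log units; beyond the scatter), where 3,4-dihydroxy-5-(hydroxymethyl)oxolan-2-yl takes the place of (5-(hydroxymethyl)-2,2-dimethyl-1,3-dioxolan-4-yl)methyl on an aromatic nitrogen.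

Compound 4 `CN(C)CCCCn1c2c(c3ccccc31)C(=O)c1c[n+]([O-])c3ccccc3c1C2=O` differs from compound 1 in one place: dimethylamino in place of 2-(4-methylpiperazin-1-yl)ethyl on a saturated chain carbon, four bonds along the chain from an aromatic nitrogen. Within the data shown here, no measured step bears on a change of this kind; the one step in hand concerns a different group at a different place, and nothing in the measured set varies the chain carried by the aromatic nitrogen of the core. The expectation for compound 4 can therefore rest only on the value of compound 1, and the step expected in this assay, a 1.2-fold lower number from compound 1 to compound 4 (0.06 log units; within the scatter), is none beyond the scatter, with a wide range to reflect the lack of any guiding step. Compound 4 is thus estimated at 5000 nM, within a range from 1500 nM to 17000 nM.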

Compound 4, half-maximal inhibitory concentration: 520 nM
The estimate for compound 4 lay 9.6-fold (0.98 log units) above the measured number; the measured number lies below the stated range.
By their numbers in this assay, from the lowest: compound 2; then compound 4; then compound 3; then compound 1.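

In this assay, the chain on the aromatic nitrogen of the shared core proves to be a place where the number can move a long way: dimethylamino in place of 2-(4-methylpiperazin-1-yl)ethyl gives an 11-fold lower number from compound 1 to compound 4 (1.05 log units; beyond the scatter). Within the data shown here, the earlier step, an 11-fold higher number from compound 2 to compound 3 (1.06 log units; beyond the scatter), concerned other groups on an aromatic nitrogen, so this is the first sign that the amine-bearing chain matters in its own right, with the shorter, ring-free tail carrying the lower number. Nothing measured here accounts for the size of this step.

This single change shortens the tail and replaces the ring-bearing amine together, so the compounds shown leave open how much of the step belongs to each: dimethylamino on a longer chain, or 4-methylpiperazin-1-yl on a shorter one, would be needed to pull the two apart. Also open, from the compounds shown here alone, is whether a primary amine or a carboxylic acid at the end of the same chain would give a number closer to that of compound 4 or to that of compound 1.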